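Swapping a Thiophene Substituent on a Pyridine Core

The source may report more compounds than this note shows. Statements on the series, on what has been measured and on what is new or still open speak of the compounds shown alone.

Measured compounds:
Compound 1, `Cc1ccsc1-c1cc(-c2ccco2)cc(-c2ccc(Cl)cc2)n1`: 24500 nM
Compound 2, `Clc1ccc(-c2cc(-c3ccco3)cc(-c3ccc(Cl)s3)n2)cc1`: 17000 nM
Compound 3, `Cc1ccsc1-c1cc(-c2ccc(Cl)o2)cc(-c2ccco2)n1`: 22200 nM

All three were tested in a functional assay on HeLa cells (Homo sapiens) for cytotoxicity, read by ELISA, with a stated time of 4 days; a higher number here means a weaker inhibitor, a lower number a stronger inhibitor. Compound 1 and compound 2 share a core and differ in one place: 5-chlorothiophen-2-yl in place of 3-methylthiophen-2-yl on an aromatic carbon. This change gave a 1.4-fold lower number from compound 1 to compound 2 (0.16 log units; within the scatter), so the two values cannot be told apart with confidence. Compound 3 carries a different core; how its core differs from that of compound 1 is not broken down here, and its value sits close to both of the others.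

The unmeasured compound 4, `Clc1ccc(-c2cc(-c3ccco3)nc(-c3ccc(Cl)s3)c2)o1`, relates to compound 3 in the same kind of way that compound 2 relates to compound 1: 5-chlorothiophen-2-yl in place of 3-methylthiophen-2-yl on an aromatic carbon. The surroundings of the exchanged group are not identical, though. In compound 1 the place is meta to a 4-chlorophenyl group, whereas in compound 3 it is meta to a 5-chlorofuran-2-yl group; in both cases the place is next to the ring nitrogen and meta to a furan-2-yl group. Within the data shown here, since the one earlier example of this change gave a step within the scatter, a similar small step is expected here, resting only on that single pair.

Compound 4 is therefore estimated to show a 1.3-fold lower number from compound 3 to compound 4 (0.12 log units; within the scatter), giving an expected value of 17000 nM, with a likely range from 8000 nM to 35000 nM.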

Compound 4, half-maximal inhibitory concentration: > 50000 nM
Compound 4: a limit, no number; the forecaster's own chance of this, stated with the estimate: 5%; middle value at least 2.9-fold (0.46 log units) away from the limit.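

In this assay, compound 4 gives > 50000 nM, which is a limit of the assay and not a number: the limit of > 50000 nM in this assay, at which 1 of the 4 values shown sits.

Putting 5-chlorothiophen-2-yl in place of 3-methylthiophen-2-yl gave an at least 2.2-fold higher number from compound 3 to compound 4 (0.35 log units; beyond the scatter), so an exchange that changed little on one core did not behave the same way on the other: the same change on two cores in this assay, a 1.4-fold lower number (0.16 log units; within the scatter) from compound 1 to compound 2 and an at least 2.2-fold higher number (0.35 log units; beyond the scatter) from compound 3 to compound 4, at least 3.2-fold (0.51 log units) apart, beyond the scatter of two such steps

Among these compounds, this shows that, in this series, the result of the exchange on the core of compound 1 cannot simply be carried over to the core of compound 3, but it rests on only two pairs and does not show which difference between the cores matters, whether the 4-chlorophenyl group of compound 1, the 5-chlorofuran-2-yl group of compound 3, or something else, and the limit also leaves the full size of the step unknown.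

The compounds shown leave open whether the exchange would follow either of these two results on a third core, so no general rule for the series can be drawn from them. They also leave open what would happen if a polar group such as an amine or a carboxylic acid stood on the thiophene in place of the chlorine or the methyl.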